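Sulfonamide series at the growth hormone secretagogue receptor

The compounds below may be only part of what the source reports. "The series", "measured", "known", "first", "only" and "open" are said of these compounds alone.

Measured so far:
compound 1 `C[C@@H]1CN(c2ccc(Cl)c(NS(=O)(=O)c3ccc(-c4ccccn4)s3)c2)C[C@H](C)N1` — 39.8 nM
compound 2 `COc1cccc(-c2ccc(S(=O)(=O)Nc3cc(N4C[C@@H](C)N[C@@H](C)C4)ccc3OC)cc2)c1` — 2 nM

In a functional assay for agonist activity at growth hormone secretagogue receptor type 1 (Homo sapiens), read by FLIPR (on this read-out higher numbers stand for an effect only at larger amounts of compound and lower numbers for an effect already at smaller amounts), compound 1 gives 39.8 nM, while compound 2 gives 2 nM. Compound 2 has the lower of the two numbers; compound 1 lies above it by a gap well beyond the scatter. Within the data shown here, no pair differing in a single place has been measured, so no single-step effect is known.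

Compound 3 `COc1ccc(N2C[C@@H](C)N[C@@H](C)C2)cc1NS(=O)(=O)c1ccc(N2CCCC2=O)cc1` has not yet been measured. It differs from compound 2 by 2-oxopyrrolidin-1-yl in place of 3-methoxyphenyl on an aromatic carbon. Among the measured compounds shown here, no measured step shows what replacing the 3-methoxyphenyl by a smaller, non-aromatic 2-oxopyrrolidin-1-yl does in this assay. The expectation is a moderate rise in the number, beyond the scatter, the step from compound 2 to compound 3 being estimated at a 6.0-fold higher number from compound 2 to compound 3 (0.78 log units; beyond the scatter). For compound 3 the estimate in this assay is 12 nM, with a range from 3 nM to 60 nM.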

Compound 3, half-maximal effective concentration: 39.8 nM
Compound 3: the middle estimate sits 3.3-fold (0.52 log units) below what was measured; the range from low to high includes it.
By their numbers in this assay, from the lowest: compound 2; then compounds 1 and 3 (each within the scatter of the next).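

Among these compounds, this is the first single-place step. In this assay, 2-oxopyrrolidin-1-yl in place of 3-methoxyphenyl on an aromatic carbon, para to a large group, gives a 20-fold higher number from compound 2 to compound 3 (1.30 log units; beyond the scatter) and so a large change beyond the scatter. The position is therefore not indifferent to its substituent: the number responds strongly even though the two groups carry the same count of hydrogen-bond donors and acceptors and neither has a net charge, and no measurement at hand accounts for the step.

The compounds shown leave open whether the aromatic ring or the carbonyl of the entering group matters more for this step. A plain phenyl, or a piperidin-1-yl ring without a carbonyl, at the same position would help separate the two.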